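A few compounds are considered here, and "the series" means these few. Any claim that something is new, unique, unknown or untested is made for them only; others in the source may bear on it.

Measured so far in an ADME assay on S9 fraction from liver (Rattus norvegicus) for metabolic stability, with a stated time of 1 h; a higher number here means that more of the compound is left, a lower number that less of the compound is left:
compound 1 `N#Cc1cnc(NCc2cnccc2C(F)(F)F)cc1N[C@H]1C[C@@H](O)C1` gives 70%
compound 2 `N#Cc1cnc(NCc2cnccc2C(F)(F)F)cc1NC[C@H]1C[C@H](O)C1` gives 61%

Compound 2 lies within the scatter of compound 1, so neither stands apart on these two numbers. Compound 3 (`N#Cc1cnc(NCc2cnccc2C(F)(F)F)cc1N[C@H]1CC[C@H](O)CC1`) differs from compound 2 by one change (4-hydroxycyclohexyl in place of (3-hydroxycyclobutyl)methyl on a nitrogen on an aromatic ring) on a nitrogen on an aromatic ring. Going by the values given here, the only measured step at that nitrogen (a number 9 percentage points lower from compound 1 to compound 2 (within the scatter)) stays within the scatter. No data yet cover a six-membered ring there, so no step beyond the scatter is expected in this assay for this change. The estimated step is small (a number 1 percentage points lower from compound 2 to compound 3 (within the scatter)). Compound 3 is expected at (60%), with an estimated range (42% to 78%).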

Compound 3, percent of the compound remaining: 25%
The estimate for compound 3 lay 35 percentage points above the measured number; the measured number lies below the stated range.
By their numbers in this assay, from the lowest: compound 3; then compounds 2 and 1 (each within the scatter of the next).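

At the nitrogen on an aromatic ring, this assay proves sensitive to the group carried there: 4-hydroxycyclohexyl in place of (3-hydroxycyclobutyl)methyl gives a number 36 percentage points lower from compound 2 to compound 3 (beyond the scatter), and 4-hydroxycyclohexyl in place of 3-hydroxycyclobutyl gives a number 45 percentage points lower from compound 1 to compound 3 (beyond the scatter). Going by these compounds alone, the two groups with a four-membered ring had not separated, so compound 3, with its six-membered ring, is the first compound here to stand apart. Nothing available accounts for this drop. The compounds shown leave open whether the six-membered ring alone goes with the lower number or its hydroxyl group also plays a part. A 3-hydroxycyclopentyl or a plain cyclohexyl group at this nitrogen would bear on that question.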